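The source may hold more compounds than are shown below. What is called first, only, known or untested is meant among the compounds shown, and "the series" means these compounds.

Measured so far:
Compound 1 `CCC(=O)c1ccc2c(c1)C(n1ccccc1=O)=CC(C)(C)O2` gives 5.85.
Compound 2 `CC1(C)C=C(n2ccccc2=O)c2cc(C(=O)c3cccs3)ccc2O1` gives 5.84.
Compound 3 `CC1(C)C=C(n2ccccc2=O)c2cc(C(=O)c3ccco3)ccc2O1` gives 5.92.

All three numbers come from a functional assay (trachea) with Rattus norvegicus as the target; on this read-out lower numbers stand for lower potency and higher numbers for higher potency (the scale is a negative logarithm). Compound 1 holds the second highest of the three, yet its nearest neighbour, compound 2, and its furthest, compound 3, both lie within the scatter of it, so no order among the three can be claimed.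

Compound 4 `CC1(C)C=C(n2ccccc2=O)c2cc(C(=O)c3ccccc3[N+](=O)[O-])ccc2O1` differs from compound 1 in one place: 2-nitrophenyl in place of ethyl on a carbonyl carbon. Going by the values given here, two measured steps bear on this change, since both also replaced the ethyl on the carbonyl carbon with an aromatic ring: a number 0.01 log units lower from compound 1 to compound 2 (within the scatter), where thiophen-2-yl entered, and a number 0.07 log units higher from compound 1 to compound 3 (within the scatter), where furan-2-yl entered. Neither moved the number beyond the scatter. A 2-nitrophenyl ring is larger than either, but the shown steps give no sign that a ring on that carbonyl carbon shifts the read-out, so no step beyond the scatter is expected: a number 0.05 log units higher from compound 1 to compound 4 (within the scatter). The estimate for compound 4 is therefore 5.9, with a range from 5.4 to 6.4.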

Compound 4, logarithm of the reciprocal of the active concentration, log(1/C): 5.64
Compound 4: middle estimate off by 0.26 log units, on the high side, and the stated range covers the measured number.
By their numbers in this assay, from the lowest: compounds 4, 2, 1 and 3 (each within the scatter of the next).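

On the carbonyl carbon, 2-nitrophenyl in place of ethyl stays within the usual scatter in this assay: a number 0.21 log units lower from compound 1 to compound 4 (within the scatter). Going by these compounds alone, the same holds against the two other rings, with a number 0.28 log units lower from compound 3 to compound 4 (within the scatter) and a number 0.20 log units lower from compound 2 to compound 4 (within the scatter), so this place has now taken a six-membered aromatic ring of carbon only, with a nitro group on it, and no step among the four compounds goes beyond the scatter. No measurement at hand explains these numbers.

Still open is whether any group on this carbonyl carbon can move the number beyond the scatter, since only ethyl and three aromatic rings are shown there. A plain phenyl, an amine, a carboxylic acid or a longer chain in that place could each answer this, and plain phenyl would also show what the nitro group itself contributes.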